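The compounds below may be only part of what the source reports. "The series", "measured", "known", "first", "only" and "open" are said of these compounds alone.

Measured so far:
compound 1, `O=C(Nc1ccc(F)cc1)N1CCN(S(=O)(=O)c2sccc2-c2ccccc2Oc2ccc(O)c(O)c2)CC1`, 6800 nM
compound 2, `COc1ccc(Oc2ccccc2-c2ccsc2S(=O)(=O)N2CCN(C(=O)Nc3ccc(F)cc3)CC2)cc1OC`, 14900 nM

Both were tested in a functional assay on RS4-11 cells (Homo sapiens) for inhibition, read by CCK-8 assay, with a stated time of 48 h; on this read-out higher numbers stand for weaker inhibition and lower numbers for stronger inhibition. Among the measured compounds shown here, compound 1 gives the lower of the two numbers; its only neighbour is compound 2, and the step between them is a 2.2-fold higher number from compound 1 to compound 2 (0.34 log units; beyond the scatter), a change of the dihydroxyphenyl for a dimethoxyphenyl on the aromatic oxygen. Compound 3, `O=S(=O)(c1sccc1-c1ccccc1Oc1ccc(O)c(O)c1)N1CCN(C(=S)Nc2ccc(Cl)cc2)CC1`, has not yet been measured. It differs from compound 1 at another place altogether: a group of 10 heavy atoms (7 carbon, 1 nitrogen, 1 sulfur, 1 chlorine; one six-membered aromatic ring of carbon only) in place of a group of 10 heavy atoms (7 carbon, 1 nitrogen, 1 oxygen, 1 fluorine; one six-membered aromatic ring of carbon only), on an amine nitrogen in a ring. The group that leaves is the (4-fluorophenyl)carbamoyl; the group that enters has no common name and carries sulfur and chlorine where the old group carried oxygen and fluorine. For the measured compounds named here, no measured step touches this ring nitrogen, so among the two numbers there is nothing that speaks for a move in either direction, and the expectation is a step within the scatter. Compound 3 is therefore expected to give roughly 7000 nM in this assay, with a range from 2500 nM to 20000 nM. That corresponds to an expected step of a 1.0-fold higher number from compound 1 to compound 3 (0.01 log units; within the scatter).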

Compound 3, half-maximal inhibitory concentration: 7500 nM
Compound 3: middle estimate off by 1.1-fold (0.03 log units), on the low side; the measured number falls inside the stated range.
By their numbers in this assay, from the lowest: compounds 1, 3 and 2 (each within the scatter of the next, the first and the last beyond it).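

In this assay, among the compounds shown here, this is the first measured step at the group on the amine nitrogen in the ring, and a 1.1-fold higher number from compound 1 to compound 3 (0.04 log units; within the scatter) is what this place gives when sulfur stands in for oxygen and chlorine for fluorine in the same exchange. The earlier pair spoke only of the dihydroxyphenyl end of the molecule, so this step adds something new: the far end of the molecule can carry these two atom exchanges together without a difference that can be told from the scatter. No other measurement comes with these compounds, so nothing shown here explains the result.

Because both exchanges arrive together, the step cannot say what each does alone: the two could have no effect on their own, or they could pull in opposite directions and cancel, and only a compound with a single exchange, such as the (4-chlorophenyl)carbamoyl group, could separate them. Going by these compounds, it also remains open whether this place stays as undemanding with a quite different group on the ring nitrogen, such as an acetyl or a benzyl, and whether the dimethoxyphenyl step seen at the other end holds with the sulfur and chlorine group in place.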